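The source may report more compounds than this note shows. Statements on the series, on what has been measured and on what is new or still open speak of the compounds shown alone.

Compound 1 `Cc1csc(-c2cncc(Cl)c2N2CCC3(CCNC3=O)CC2)c1` stands lowest of the two numbers recorded in a functional assay on MV4-11 cells (Homo sapiens) for inhibition, read by resazurin assay, with a stated time of 72 h (on this read-out higher numbers stand for weaker inhibition of growth and lower numbers for stronger inhibition of growth), where compound 1 gives 650 nM; compound 2 `CC(C)(C)OC(=O)N1CCN(Cc2ccc(-c3cncc(Cl)c3N3CCC4(CCNC4=O)CC3)s2)CC1` sits far higher in this assay at 5150 nM, a gap beyond the scatter. Compound 3 `Cn1cc(-c2cncc(Cl)c2N2CCC3(CCNC3=O)CC2)cn1` has not yet been measured. Against compound 1 the change is 1-methyl-1H-pyrazol-4-yl in place of 4-methylthiophen-2-yl on an aromatic carbon. Among the compounds with values here, no single-change step between measured compounds exists to guide the size of this swap, so the expectation rests on compound 1 alone and is taken as a modest weakening in this assay, a 2.0-fold higher number from compound 1 to compound 3 (0.30 log units; within the scatter), though a step within the scatter cannot be excluded. Compound 3 is accordingly expected to give 1300 nM, within 400 nM to 4500 nM.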

Compound 3, concentration for 50% growth inhibition: 5530 nM
Compound 3: middle estimate off by 4.3-fold (0.63 log units), on the low side; measured number outside the range, above it.
By their numbers in this assay, from the lowest: compound 1; then compounds 2 and 3 (each within the scatter of the next).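

Read in this assay, the swap of 4-methylthiophen-2-yl for 1-methyl-1H-pyrazol-4-yl on this aromatic carbon gives an 8.5-fold higher number from compound 1 to compound 3 (0.93 log units; beyond the scatter) and so costs growth inhibition beyond the scatter. This position therefore distinguishes between two five-membered aromatic rings of equal heavy-atom count, one with a sulfur and one with two nitrogens. Nothing available accounts for this difference.

Still open, from the compounds shown here alone, is how a phenyl ring, a thiazole or an unmethylated thiophen-2-yl would read at this carbon. Also open, going by these compounds, is whether the methyl group contributes on either ring.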